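Thiourea analogue with a 2-hydroxyphenyl group awaits testing

A few compounds are considered here, and "the series" means these few. Any claim that something is new, unique, unknown or untested is made for them only; others in the source may bear on it.

Measured so far in a functional assay, with a stated time of 20 min, tested at 50 uM; a lower number here means a weaker effect, a higher number a stronger effect of the compound at the concentration tested:
compound 1 `COc1cc(/C=C/C(=O)C2=C(/C=C/c3ccc(O)c(OC)c3)NC(=O)NC2c2ccc(C)cc2)ccc1O` gives 52.2%;
compound 2 `COc1cc(/C=C/C(=O)C2=C(/C=C/c3ccc(O)c(OC)c3)NC(=O)NC2c2ccccc2O)ccc1O` gives 88%;
compound 3 `COc1cc(/C=C/C(=O)C2=C(/C=C/c3ccc(O)c(OC)c3)NC(=S)NC2c2ccc(C)cc2)ccc1O` gives 41%.

Compound 1 and compound 2 share a core and differ in one place: 2-hydroxyphenyl in place of 4-methylphenyl on a saturated ring carbon. In this assay this change made a step of a number 35.8 percentage points higher from compound 1 to compound 2 (beyond the scatter), beyond the scatter. Compound 3 gives the lowest of the three numbers; compared with compound 1 it sits lower, and the difference between the two cores is not broken down here.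

Compound 4 `COc1cc(/C=C/C(=O)C2=C(/C=C/c3ccc(O)c(OC)c3)NC(=S)NC2c2ccccc2O)ccc1O` is the partner of compound 3 in the same kind of change: 2-hydroxyphenyl in place of 4-methylphenyl on a saturated ring carbon. The place line is the same word for word as for compound 1 to compound 2, so it is the same change on a different core. If it carries over, compound 4 is expected to rise by about a number 34 percentage points higher from compound 3 to compound 4 (beyond the scatter) from compound 3, resting on the step of a number 35.8 percentage points higher from compound 1 to compound 2 (beyond the scatter) seen on the other core. The estimate for compound 4 in this assay is therefore 75%, within a range from 58% to 92%.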

Compound 4, a percentage reported as activity, at one concentration (the size of the read-out at that concentration, not a potency): 88.5%
Compound 4: middle estimate off by 13.5 percentage points, on the low side; measured number inside the range.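

In this assay, 2-hydroxyphenyl in place of 4-methylphenyl on a saturated ring carbon again raised the read-out, giving a number 47.5 percentage points higher from compound 3 to compound 4 (beyond the scatter), so the change carried over from one core to the other. The two steps point the same way and do not differ in size beyond what repeated measurements allow: the same change on two cores in this assay, a number 35.8 percentage points higher (beyond the scatter) from compound 1 to compound 2 and a number 47.5 percentage points higher (beyond the scatter) from compound 3 to compound 4, 11.7 percentage points apart, within the scatter of two such steps. This rests on a single pair on each of two cores, at one concentration in one assay, so it shows that the change carries across these two cores only; it does not show which feature of the entering group is responsible, or that the same would hold on any further core.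

The compounds shown leave open how a phenyl group bearing an amine or a carboxylic acid instead of the hydroxyl would read at that ring carbon. Also open, going by these compounds, is whether the steps keep their size at other concentrations, since each compound is reported at a single concentration.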